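Adding one methyl to the pyrimidine of compound 2

The compounds below may be only part of what the source reports. "The series", "measured", "known", "first", "only" and "open" are said of these compounds alone.

In a toxicity assay on HT-29 cells (Homo sapiens) for cytotoxicity (a higher number here means that more compound is tolerated, a lower number that less compound is tolerated), compound 1 `CN1C(=S)[C@@H](NC(=O)c2nc(Cc3ccccc3)n(CCCO)n2)COc2ccccc21` gives > 100000 nM, which is a limit and not a number. In this assay, compound 2 `CN1C(=S)[C@@H](NC(=O)c2nc(Cc3ccccc3)n(-c3ncccn3)n2)COc2ccccc21` gives > 100000 nM, again a limit and not a number. The series therefore offers only (the limit of > 100000 nM in this assay, at which 2 of the 2 values shown sit). Among the compounds with values here, the one measured change, a step that the two limits leave unreadable from compound 1 to compound 2, has no readable size, so it sets no scale for what follows.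

Compound 3 `Cc1cnc(-n2nc(C(=O)N[C@H]3COc4ccccc4N(C)C3=S)nc2Cc2ccccc2)nc1` differs from compound 2 by methyl in place of hydrogen on an aromatic carbon, taking pyrimidin-2-yl to 5-methylpyrimidin-2-yl. Neither measured compound gives a number to work from, so any expectation is weakly grounded. No shift beyond the usual scatter is expected, and no direction is assigned. The expected size is a number no higher from compound 2 to compound 3 (the limit leaves the size open). For compound 3 the estimated value is 100000 nM, with an expected range of 50000 nM to 200000 nM, and a further limit is the likeliest report.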

Compound 3, half-maximal cytotoxic concentration: > 100000 nM
Compound 3: no number, only a limit; the forecaster's own chance of this, stated with the estimate: 85%; the middle value sits exactly at the limit.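

Compound 3 gives > 100000 nM as a limit and not a number. No new step can be read between compound 3 and either compound 1 or compound 2. Left open in this assay is whether the 3-hydroxypropyl, pyrimidin-2-yl and 5-methylpyrimidin-2-yl groups differ at all: the limit of > 100000 nM in this assay, at which 3 of the 3 values shown sit.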